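Changing the aryl group on the hydrazone carbon

A few compounds are considered here, and "the series" means these few. Any claim that something is new, unique, unknown or untested is made for them only; others in the source may bear on it.

Measured so far:
Compound 1 `CN(C)CCn1cnnc1-c1cc(Oc2ccc(NC(=O)N/N=C/c3ccc(Cl)cc3Cl)cc2F)ccn1` gives 130 nM in a functional assay on NCI-H460 cells (Homo sapiens) for cytotoxicity, read by MTT assay, with a stated time of 72 h; a higher number here means a weaker inhibitor, a lower number a stronger inhibitor.
Compound 2 `CN(C)CCn1cnnc1-c1cc(Oc2ccc(NC(=O)N/N=C/c3ccccc3O[N+](=O)[O-])cc2F)ccn1` gives 1270 nM in this assay.
Compound 3 `CN(C)CCn1cnnc1-c1cc(Oc2ccc(NC(=O)N/N=C/c3ccc(F)cc3F)cc2F)ccn1` gives 1930 nM in this assay.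

Compound 3 has the highest number of the three in this assay: against compound 1 the gap is a 15-fold higher number from compound 1 to compound 3 (1.17 log units; beyond the scatter), against compound 2 only a 1.5-fold higher number from compound 2 to compound 3 (0.18 log units; within the scatter), which does not stand out from the noise. Compound 4 `COc1cc(/C=N/NC(=O)Nc2ccc(Oc3ccnc(-c4nncn4CCN(C)C)c3)c(F)c2)ccc1O` differs from compound 3 at a single place: 4-hydroxy-3-methoxyphenyl in place of 2,4-difluorophenyl on a carbon with a double bond to nitrogen. Two earlier exchanges at this same place inform the expectation. One, a 9.8-fold higher number from compound 1 to compound 2 (0.99 log units; beyond the scatter), and the other, a 15-fold higher number from compound 1 to compound 3 (1.17 log units; beyond the scatter), both weakened the effect, while a 1.5-fold higher number from compound 2 to compound 3 (0.18 log units; within the scatter) shows two such replacements landing close together. A new aryl group at this position is therefore expected to leave compound 4 near compound 3, with the step estimated as a 1.3-fold higher number from compound 3 to compound 4 (0.11 log units; within the scatter). Compound 4 is estimated at 2500 nM, within 800 nM to 8000 nM.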

Compound 4, half-maximal inhibitory concentration: 57 nM
For compound 4 the middle estimate is 44-fold (1.64 log units) above the measured one; measured number below the stated range.
By their numbers in this assay, from the lowest: compound 4; then compound 1; then compounds 2 and 3 (each within the scatter of the next).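

In this assay the new aryl group gives a 34-fold lower number from compound 3 to compound 4 (1.53 log units; beyond the scatter) and a 22-fold lower number from compound 2 to compound 4 (1.35 log units; beyond the scatter) and also a 2.3-fold lower number from compound 1 to compound 4 (0.36 log units; beyond the scatter) in one comparison each. Until now every replacement of 2,4-dichlorophenyl had raised the number, so this position can also improve on compound 1, and 4-hydroxy-3-methoxyphenyl gives the lowest number of the four. No measurement shown explains this gain. The compounds shown leave open whether the hydroxy group or the methoxy group alone would give the same number. They also leave open what an amine in place of the hydroxy group would do.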